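Methoxy for fluoro on the aromatic ring of compound 2

The compounds below may be only part of what the source reports. "The series", "measured", "known", "first", "only" and "open" are said of these compounds alone.

In a functional assay on HepG2 cells (Homo sapiens) for inhibition, read by MTT assay, with a stated time of 72 h (a lower number here means a stronger inhibitor, a higher number a weaker inhibitor), compound 1 `C=C(c1ccc(Cl)cc1Cl)C1COC2(CCCCC2)OO1` gives 17600 nM. Compound 2 `C=C(c1ccc(F)c(F)c1)C1COC2(CCCCC2)OO1` gives 28600 nM in this assay, a number that lies within the usual scatter of the number for compound 1, so the two cannot be ranked against each other. Compound 3 `C=C(c1ccc(OC)c(F)c1)C1COC2(CCCCC2)OO1` differs from compound 2 in one place: methoxy in place of fluoro on an aromatic carbon. Going by the values given here, no measured pair in this set shows what such a change does, so the step from compound 2 to compound 3 is expected to stay within the scatter, as a 1.1-fold lower number from compound 2 to compound 3 (0.06 log units; within the scatter). In this assay compound 3 is therefore estimated at 25000 nM, in a range from 8000 nM to 80000 nM.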

Compound 3, half-maximal inhibitory concentration: 13100 nM
The estimate for compound 3 lay 1.9-fold (0.28 log units) above the measured number, and the stated range covers the measured number.
By their numbers in this assay, from the lowest: compounds 3, 1 and 2 (each within the scatter of the next, the first and the last beyond it).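

In this assay, going by these compounds alone, methoxy in place of fluoro on this aromatic carbon, ortho to a fluoro group and para to a large group, gives the first single-place step in the set: a 2.2-fold lower number from compound 2 to compound 3 (0.34 log units; beyond the scatter). The step is modest, but it shows that this carbon takes a group of two heavy atoms with no loss in the read-out. No measurement at hand accounts for the step. Going by these compounds, whether an ethoxy group, a hydroxyl or an amine on this carbon would act alike remains open, as does the same change without the ortho fluoro group.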